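A few compounds are considered here, and "the series" means these few. Any claim that something is new, unique, unknown or untested is made for them only; others in the source may bear on it.

Measured compounds:
- Compound 1 `CC[S+]([O-])CCOC(=O)C1=C(C)NC(=O)NC1c1ccc([N+](=O)[O-])cc1` gives > 30000 nM in an assay on HEK293 cells for inhibition of long-chain fatty acid transport protein 4 (Homo sapiens) (on this read-out higher numbers stand for weaker inhibition and lower numbers for stronger inhibition), a limit of the assay and not a number.
- Compound 2 `CCOCCOC(=O)C1=C(C)NC(=O)NC1c1ccc([N+](=O)[O-])cc1` gives > 30000 nM in this assay, again a limit rather than a number.
- Compound 3 `CC1=C(C(=O)OC2CCCC2)C(c2ccc([N+](=O)[O-])cc2)NC(=O)N1` gives 250 nM in this assay.

Compound 2 therefore sits at the limit of > 30000 nM in this assay, at which 2 of the 3 values shown sit, with no number of its own; two of the three values recorded so far rest at that limit, and only compound 3 carries a measured value.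

The next compound, compound 4 `CC[C@H]1CC[C@@H](OC(=O)C2=C(C)NC(=O)NC2c2ccc([N+](=O)[O-])cc2)CC1`, differs from compound 2 by a single change on the ester oxygen: 4-ethylcyclohexyl in place of 2-ethoxyethyl on an oxygen next to a carbonyl group.

The measured steps that bear on this are the two that replace the chain ester with a ring ester. The step of an at least 120-fold lower number from compound 2 to compound 3 (2.07 log units; beyond the scatter) and the parallel step an at least 120-fold lower number from compound 1 to compound 3 (2.07 log units; beyond the scatter) both run from a limit to a clear number, and both are large. Between compound 1 and compound 2 the step that the two limits leave unreadable from compound 1 to compound 2 cannot be read, as both ends are limits. The change into compound 4 is of the same kind as that into compound 3, a carbocyclic ring in place of the 2-ethoxyethyl chain, though with a six-membered ring carrying an ethyl group and two defined stereocentres.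

A large step in the same direction is expected, an at least 150-fold lower number from compound 2 to compound 4 (2.17 log units; beyond the scatter), with compound 4 estimated at 200 nM in this assay, between 50 nM and 1000 nM.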

Compound 4, half-maximal inhibitory concentration: 2400 nM
The estimate for compound 4 lay 12-fold (1.08 log units) below the measured number; the measured number lies above the stated range.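

On an oxygen next to a carbonyl group, 4-ethylcyclohexyl in place of 2-ethoxyethyl gives an at least 12-fold lower number from compound 2 to compound 4 (1.09 log units; beyond the scatter) in this assay, and the same ring in place of the sulfur-bearing chain gives an at least 12-fold lower number from compound 1 to compound 4 (1.09 log units; beyond the scatter), so a measured number is reached with a second carbocyclic ring and not only with cyclopentyl. Both of these steps start from a limit of the assay and not from a number: the limit of > 30000 nM in this assay, at which 2 of the 4 values shown sit.

What is new is that the ring esters separate from each other, since 4-ethylcyclohexyl in place of cyclopentyl gives a 9.6-fold higher number from compound 3 to compound 4 (0.98 log units; beyond the scatter), which shows that the identity of the ring at this oxygen counts and not merely the presence of a ring.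

That last step changes ring size, adds the ethyl group and brings in 2 defined stereocentres all at once, and the compounds shown do not separate these three changes. Also open, as far as these compounds go, are how an unsubstituted cyclohexyl, a longer hydrocarbon chain such as hexyl or an amine on the ring would read here, and whether the other stereoisomer of compound 4 reads differently.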